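The compounds below may be only part of what the source reports. "The series", "measured", "known", "first", "only" and "open" are said of these compounds alone.

Measured compounds:
- compound 1, `COc1cc(C)cc(-c2c(-c3ccnc(-c4ccc(C(C)=O)cc4)c3)cnn2CC#N)c1`: in a functional assay on UACC-62 cells (Homo sapiens) for inhibition, read by sulforhodamine B assay, with a stated time of 48 h (a lower number here means that less compound is tolerated, a higher number that more compound is tolerated), compound 1 gives > 100000 nM, which is a limit of the assay and not a number.
- compound 2, `COc1cc(C)cc(-c2nn(CC#N)cc2-c2ccc(-c3cccc(C(C)=O)c3)nc2)c1`: compound 2 gives > 100000 nM, again a limit.
- compound 3, `COc1cc(C)cc(-c2nn(CC#N)cc2-c2ccnc(-c3ccc(N(C)C)cc3)c2)c1`: compound 3 gives > 100000 nM, again a limit.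

Among the measured compounds shown here, compound 1 therefore stands nowhere in particular on these numbers: every value shown is the same limit, and the limit of > 100000 nM in this assay, at which 3 of the 3 values shown sit, means no compound of this set has been told apart from another. The new compound 4, `COc1cc(C)cc(-c2c(-c3ccnc(-c4ccc(N(C)C)cc4)c3)cnn2CC#N)c1`, differs from compound 1 in one place, (dimethylamino in place of acetyl on an aromatic carbon), that is, dimethylamino in place of acetyl on an aromatic carbon. For the measured compounds named here, no step between measured compounds is known, so the size of the change cannot be read from a measured pair. Since compound 3, which also carries the dimethylamino group, gave > 100000 nM, the expectation is that the step from compound 1 to compound 4, a step that the limit leaves unreadable from compound 1 to compound 4, is nothing beyond the scatter. Compound 4 is expected at 150000 nM, with a range from 50000 nM to 400000 nM, most likely reported again only as a limit.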

Compound 4, concentration lethal to 50% of the cells: > 100000 nM
Compound 4: no number, only a limit (the forecaster's own chance of this, stated with the estimate: 85%); the middle value lies beyond the limit too.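

In this assay compound 4 gives > 100000 nM, which is a limit and not a number, so no step can be read between compound 1 and compound 4. The compounds shown leave open whether acetyl and dimethylamino differ in effect, or whether any of these compounds differs from another, with all of them sharing one result: the limit of > 100000 nM in this assay, at which 4 of the 4 values shown sit.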